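Benzyl bromination carried onto the methoxy analogue

The compounds below may be only part of what the source reports. "The series", "measured", "known", "first", "only" and "open" are said of these compounds alone.

Three members of the series have numbers in a functional assay on A549 cells (Homo sapiens) for inhibition, read by MTT assay, with a stated time of 48 h, tested at 10 uM; on this read-out lower numbers stand for less inhibition of growth and higher numbers for more inhibition of growth at the one concentration tested. Compound 1 `O=C(/C=C/c1ccc(OCc2cn(Cc3ccccc3)nn2)cc1)c1ccc(Br)cc1` gives 34%. Compound 2 `O=C(/C=C/c1ccc(OCc2cn(Cc3ccccc3Br)nn2)cc1)c1ccc(Br)cc1` gives 44%, and the step of a number 10 percentage points higher from compound 1 to compound 2 (within the scatter). Compound 3 `COc1ccc(C(=O)/C=C/c2ccc(OCc3cn(Cc4ccccc4)nn3)cc2)cc1` gives 44%, with the step of a number 10 percentage points higher from compound 1 to compound 3 (within the scatter). Compound 3 thus stands level with compound 2 at the digits printed, no change between them within the scatter, and compound 1 lies within the scatter of both; none of the three numbers separates from the other two.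

Compound 4 `COc1ccc(C(=O)/C=C/c2ccc(OCc3cn(Cc4ccccc4Br)nn3)cc2)cc1` has not been measured. It differs from compound 3 by bromo in place of hydrogen on an aromatic carbon. Going by the values given here, the one measured step of the same kind is a number 10 percentage points higher from compound 1 to compound 2 (within the scatter), a shift that stays within the scatter. Among the compounds with values here, there is no precedent for the same change on a compound that already carries the methoxy group, so the expectation rests on that single step alone. For compound 4 the expected movement in this assay is a number 6 percentage points higher from compound 3 to compound 4 (within the scatter), that is, no change beyond the scatter, with at most a slight upward tendency of the kind seen between compound 1 and compound 2. Compound 4 is estimated at 50%, between 35% and 65%.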

Compound 4, percent growth inhibition at one concentration: 52%
Compound 4: the middle estimate sits 2 percentage points below what was measured, within the range that was stated.
By their numbers in this assay, from the lowest: compounds 1, 2, 3 and 4 (each within the scatter of the next, the first and the last beyond it).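

In this assay, the change from benzyl to 2-bromobenzyl on the methoxy analogue reads a number 8 percentage points higher from compound 3 to compound 4 (within the scatter), so this position now has a reading on two cores, and the two readings agree: the same change on two cores in this assay, a number 10 percentage points higher (within the scatter) from compound 1 to compound 2 and a number 8 percentage points higher (within the scatter) from compound 3 to compound 4, 2 percentage points apart, within the scatter of two such steps. The four compounds also close a square, since methoxy in place of bromo with the 2-bromobenzyl group held fixed reads a number 8 percentage points higher from compound 2 to compound 4 (within the scatter), which matches the same change with benzyl held fixed: the same change on two cores in this assay, a number 10 percentage points higher (within the scatter) from compound 1 to compound 3 and a number 8 percentage points higher (within the scatter) from compound 2 to compound 4, 2 percentage points apart, within the scatter of two such steps. Across these four compounds the two changes therefore behave as additive, with no compound going against that reading, although each single step stays within the scatter and neither change is shown on its own to alter growth inhibition.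

On these data alone, whether an amine, a carboxylic acid or chloro in place of the bromo on the benzyl group would give a step beyond the scatter stays open. With a single concentration in this assay, the compounds shown also leave open how these differences would read across a range of concentrations.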